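Aryl exchange on the ring nitrogen: efficacy working notes

This account rests on a few compounds, and the source may have more. Where it says the series, first, only, none or still open, it means among the compounds named here.

compound 1 `C/N=C1\S/C(=C\c2cc(C)n(-c3ncccc3F)c2C)C(=O)N1C`: 70%
compound 2 `CC/N=C1\S/C(=C\c2cc(C)n(-c3ncccc3F)c2C)C(=O)N1CC`: 70%

In a functional assay for agonist activity at sphingosine 1-phosphate receptor 4 (Homo sapiens) (a higher number here means a larger maximal response, a lower number a smaller maximal response), compound 1 gives 70% and compound 2 gives 70%; compound 1 is level with compound 2, the two values lying within the scatter. Compound 3 `C/N=C1\S/C(=C\c2cc(C)n(-c3cccc(F)c3)c2C)C(=O)N1C` is not yet measured. It differs from compound 1 by 3-fluorophenyl in place of 3-fluoropyridin-2-yl on an aromatic nitrogen. Among the measured compounds shown here, no step between measured compounds bears on this change, so its size is open; a small step, if any, is expected, somewhat more likely downward than upward and close to the scatter. Compound 3 is expected to give 65%, with a range of 45% to 85%. The expected step is a number 5 percentage points lower from compound 1 to compound 3 (within the scatter).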

Compound 3, largest response reached (reported as efficacy), in percent of the reference or control that the assay uses: 60%
For compound 3 the middle estimate is 5 percentage points above the measured one; measured number inside the range.
By their numbers in this assay, from the lowest: compounds 3, 1 and 2 (each within the scatter of the next).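

In this assay replacing 3-fluoropyridin-2-yl with 3-fluorophenyl on the aromatic nitrogen gives a number 10 percentage points lower from compound 1 to compound 3 (within the scatter) and so this aryl can lose its ring nitrogen without a step beyond the scatter. This is the first change shown at this position, as compound 1 and compound 2 differ elsewhere. Nothing at hand speaks to the origin of this step.

Open, from the compounds shown here alone, is what an unsubstituted phenyl, or a methoxy group in place of the fluorine, would give on the shared core. Also open, going by these compounds, is whether the exchange behaves alike on the core of compound 2.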